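Amino in Place of Trifluoromethoxy: From Compound 3 to Compound 4

The compounds below may be only part of what the source reports. "The series", "measured", "known", "first", "only" and "open" are said of these compounds alone.

Of the compounds shown here, three have been measured in an assay on isolated protein for inhibition of Rho-associated protein kinase 1 (Homo sapiens), read by scintillation counting, radiometric assay and 33P incorporation, with a stated time of 40 min, in the presence of a further agent that is not named here; on this read-out higher numbers stand for weaker inhibition and lower numbers for stronger inhibition. Compound 1, `CC(=O)c1ccc(OCC(=O)Nc2cccc(NC(=O)c3ccc(N(C)C)cc3)c2)cc1F`, gives 445 nM in this assay. Compound 3, `O=C(COc1ccc2c(=O)ccoc2c1)Nc1cccc(NC(=O)c2ccc(OC(F)(F)F)cc2)c1`, gives 869 nM in this assay. Of the two numbers shown, compound 3 carries the higher one, yet the gap to compound 1 lies within the usual scatter, so the two cannot be ranked against each other. Compound 2, `Cc1c(OCC(=O)Nc2cccc(NC(=O)c3ccc(N(C)C)cc3)c2)ccc2c(=O)ccoc12`, returns no number but a limit, > 10000 nM, which is the limit of > 10000 nM in this assay, at which 1 of the 3 values shown sits.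

Compound 4, `Nc1ccc(C(=O)Nc2cccc(NC(=O)COc3ccc4c(=O)ccoc4c3)c2)cc1`, has not yet been measured. It differs from compound 3 in one place: amino in place of trifluoromethoxy on an aromatic carbon. Among the measured compounds shown here, no step between two measured compounds that differ in a single place is available, so the change rests on compound 3 alone. The step of a 1.1-fold lower number from compound 3 to compound 4 (0.04 log units; within the scatter) is expected to stay within the usual scatter, in no clear direction. Compound 4 is therefore expected to give about 800 nM in this assay, with a range from 250 nM to 2500 nM.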

Compound 4, half-maximal inhibitory concentration: 802 nM
Compound 4: the middle estimate sits 1.0-fold (0.00 log units) below what was measured; the measured number falls inside the stated range.
By their numbers in this assay, from the lowest: compounds 1, 4 and 3 (each within the scatter of the next). At a limit, above all of these: compound 2.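

Among the compounds shown here, the step of a 1.1-fold lower number from compound 3 to compound 4 (0.03 log units; within the scatter) is the first single-place comparison, and it falls within the scatter of this assay. At this aromatic carbon, para to a large group, 4-(trifluoromethoxy)phenyl gives way to 4-aminophenyl: a group of 5 heavy atoms with no hydrogen-bond donor is replaced by one of 1 heavy atom with 1 hydrogen-bond donor, and the two compounds cannot be told apart by their numbers. No measurement shown bears on why this exchange leaves the read-out within the scatter.

On these data alone, it remains open whether a carboxylic acid, a nitrile or a longer chain at the same place would also stay within the scatter of compound 4. One step on one core also cannot show whether the same exchange would behave alike on a different core.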